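Removing One Chloro Group on Two Related Cores

The compounds below may be only part of what the source reports. "The series", "measured", "known", "first", "only" and "open" are said of these compounds alone.

Measured so far:
Compound 1, `CN1CCN(c2nc(-c3ccc(Cl)c(Cl)c3)nc3[nH]cnc23)CC1`, gives 24.1%.
Compound 2, `CN1CCN(c2nc(-c3cccc(Cl)c3)nc3[nH]cnc23)CC1`, gives 29.9%.
Compound 3, `Clc1ccc(Cl)c(-c2nc(N3CCCCC3)c3nc[nH]c3n2)c1`, gives 12.1%.

All three numbers come from an assay on cells for displacement of a labelled ligand from adenosine receptor A2b (Homo sapiens), read by scintillation counting and radioligand binding, with a stated time of 30 min, tested at 10 uM; a lower number here means less inhibition, a higher number more inhibition at the concentration tested (going by the name of the read-out). Compound 1 and compound 2 share one core and differ in a single place: hydrogen in place of chloro on an aromatic carbon. That change moved the read-out by a number 5.8 percentage points higher from compound 1 to compound 2 (within the scatter), a step that stays within the usual scatter of this assay, so the two compounds cannot be ranked against each other.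

Compound 3 carries a different core; how its core differs from that of compound 1 is not broken down here. Its number is the lowest of the three, and its gaps to compound 1 and to compound 2 both lie beyond the scatter.

Compound 4, `Clc1cccc(-c2nc(N3CCCCC3)c3nc[nH]c3n2)c1`, has not yet been measured. It stands to compound 3 as compound 2 stands to compound 1: hydrogen in place of chloro on an aromatic carbon. The surroundings are not identical, though. In the first pair the hydrogen enters ortho to a chloro group and para to a large group; in the second pair it enters ortho to a large group and para to a chloro group. It is the same kind of change, not the same change.

Among the measured compounds shown here, the only guide is the earlier step, a number 5.8 percentage points higher from compound 1 to compound 2 (within the scatter), which was small. The expected step is therefore also small, estimated at a number 4.9 percentage points higher from compound 3 to compound 4 (within the scatter). Compound 4 is thus expected to give about 17%, most likely between 5% and 30%.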

Compound 4, a percentage reported as inhibition, at one concentration (the size of the read-out at that concentration, not a potency): > 80%
Compound 4 ended at the assay's limit (the forecaster's own chance of this, stated with the estimate: 5%); middle value at least 63 percentage points from the limit.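

In this assay compound 4 gives > 80%, which is a limit of the assay and not a number. Hydrogen in place of chloro on an aromatic carbon moved the read-out by a number at least 67.9 percentage points higher from compound 3 to compound 4 (beyond the scatter), so the small step seen on the core of compound 1 did not carry over to the core of compound 3: the same change on two cores in this assay, a number 5.8 percentage points higher (within the scatter) from compound 1 to compound 2 and a number at least 67.9 percentage points higher (beyond the scatter) from compound 3 to compound 4, at least 62.1 percentage points apart, beyond the scatter of two such steps Piperidin-1-yl in place of 4-methylpiperazin-1-yl on an aromatic carbon goes with a number at least 50.1 percentage points higher from compound 2 to compound 4 (beyond the scatter), but these two pairs show only that one kind of change can give very different steps in this series, not why it does, and the limit leaves the full size of both new steps unknown.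

Still open, as far as these compounds go, is whether the large step depends on losing chloro specifically at the place ortho to a large group, which a fluoro or methoxy group at that place would help to test. Also open, from the compounds shown here alone, is whether the high read-out of compound 4 would hold with a morpholin-4-yl group in place of piperidin-1-yl, and how that read-out at one concentration relates to potency.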